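This account rests on a few compounds, and the source may have more. Where it says the series, first, only, none or still open, it means among the compounds named here.

Measured compounds in a functional assay on A549 cells (Homo sapiens) for antiproliferative activity, read by CCK-8 assay, with a stated time of 72 h; a lower number here means a stronger inhibitor of growth, a higher number a weaker inhibitor of growth:
- Compound 1 `CC[C@@H]1C(=O)N(C)c2cnc(-n3ccc4cc(F)ccc43)nc2N1C1CCCC1`: "not active" (no number reported)
- Compound 2 `CCC1C(=O)N(C)c2cnc(-n3ccc4cc(C(N)=O)ccc43)nc2N1c1ccn(C)n1`: 39500 nM
- Compound 3 `CC[C@@H]1C(=O)N(C)c2cnc(Nc3ccc(S(=O)(=O)NC4CCCC4)cc3)nc2N1C1CCCC1`: 1150 nM

Only two of these give a number. Compound 2 stands at the higher of the two, the weaker growth inhibitor; compound 3 sits at a markedly lower number, and that gap lies well beyond the scatter of repeats. Compound 1 is reported without a number, so it sets no scale here. Compounds 2 and 3 differ in several places at once, so their gap cannot be tied to any single change.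

Compound 4 `CCC1C(=O)N(C)c2cnc(-n3ccc4cc(C(=O)NC)ccc43)nc2N1c1ccn(C)n1` is the next entry. It differs from compound 2 in one spot only: methyl in place of hydrogen on an amide-type nitrogen. For the measured compounds named here, no pair of measured compounds separates this change from others, so there is no measured step to lean on. The change is small in what it adds, and on its own it is expected to move the number little: the expected step from compound 2 to compound 4 is a 1.1-fold lower number from compound 2 to compound 4 (0.05 log units; within the scatter), which is none beyond the scatter. Compound 4 is therefore estimated at 35000 nM in this assay, with a range from 9000 nM to 140000 nM.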

Compound 4, concentration for 50% growth inhibition: 43100 nM
Compound 4: the middle estimate sits 1.2-fold (0.09 log units) below what was measured; the measured number falls inside the stated range.
By their numbers in this assay, from the lowest: compound 3; then compounds 2 and 4 (each within the scatter of the next).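

In this assay, for the compounds shown here, methyl in place of hydrogen on the amide-type nitrogen gives a 1.1-fold higher number from compound 2 to compound 4 (0.04 log units; within the scatter) and is the first step that isolates a single change. At this position, going from carbamoyl to methylcarbamoyl therefore produces no separation that can be read beyond the scatter, so the amide hydrogen can be exchanged for methyl with no measurable consequence in this pair. No available measurement offers an explanation for this outcome.

Still open, from the compounds shown here alone, is whether a longer chain on this nitrogen, such as ethyl or hydroxyethyl, or a second methyl would stay as close to compound 2. Also open, going by these compounds, is whether a carboxylic acid or a nitrile in place of the whole carbamoyl group would separate from compound 2 in this assay and by how much.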